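The source may hold more compounds than are shown below. What is called first, only, known or untested is meant among the compounds shown, and "the series" means these compounds.

Three compounds with measured numbers stand at the start of this account. Compound 1 `CON(C)C(=O)c1sc(-c2ccccc2O)nc1O` gives 66 nM in an assay on HEK293 cells for inhibition of transient receptor potential cation channel subfamily M member 8 (Homo sapiens), read by FLIPR, with stated times of 5 min and 3 min; a higher number here means a weaker inhibitor, a lower number a stronger inhibitor. Compound 2 `CCn1nnc(-c2sc(-c3ccc(O)cc3)nc2O)n1` gives 11600 nM in this assay, and compound 3 `CCn1nnc(-c2sc(-c3c(Cl)cccc3Cl)nc2O)n1` gives 16500 nM in this assay. Among these three numbers compound 2 stands second highest; its nearest neighbour is compound 3, whose number lies within the usual scatter of it, while compound 1 lies far below and well beyond the scatter. Compound 2 and compound 3 therefore cannot be ordered against each other, whereas compound 1 is clearly the stronger inhibitor of the three.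

The step of interest leads from compound 2 to compound 4 `CCn1nnc(-c2sc(-c3ccc(F)cc3)nc2O)n1`, which has not yet been measured. The change is fluoro in place of hydroxy on an aromatic carbon. Among the measured compounds shown here, no measured pair shows this same change, so the size of the step cannot be read from a comparable step and has to be expected from the numbers at hand. Both compound 2 and compound 3 give high numbers in this assay, and the change exchanges one small group for another. The step of a 1.3-fold higher number from compound 2 to compound 4 (0.11 log units; within the scatter) is expected to be none beyond the usual scatter. Compound 4 is accordingly estimated at 15000 nM, with a range from 5000 nM to 45000 nM.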

Compound 4, half-maximal inhibitory concentration: 286 nM
The estimate for compound 4 lay 52-fold (1.72 log units) above the measured number; the measured number lies below the stated range.
By their numbers in this assay, from the lowest: compound 1; then compound 4; then compounds 2 and 3 (each within the scatter of the next).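

In this assay, fluoro in place of hydroxy, on an aromatic carbon of a six-membered aromatic ring of carbon only and para to a large group, gives a 41-fold lower number from compound 2 to compound 4 (1.61 log units; beyond the scatter). The earlier compounds shown here included no pair differing in one place, and this step now shows that exchanging one heavy atom for another at this position, with the hydrogen-bond donor and acceptor counted on hydroxy absent from fluoro, is enough to move the number well beyond the scatter. No measurement at hand says why the number moves so far with this change.

The compounds shown leave open whether this position favours fluoro in particular, since a plain hydrogen, chloro, methoxy or an amine in the same place could give a number near that of compound 4, near that of compound 2 or elsewhere. They also leave open whether fluoro in place of hydroxy would give a step of similar size on the core of compound 1.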